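Replacing Thiophene with Pyridine in Compound 1

A few compounds are considered here, and "the series" means these few. Any claim that something is new, unique, unknown or untested is made for them only; others in the source may bear on it.

Among the measured compounds shown here, compound 1 `COc1cc(OC)c(C(=O)/C=C/c2cn(-c3ccccc3)nc2-c2ccsc2)c(OC)c1` gives 2700 nM in a functional assay on MCF7 cells (Homo sapiens) for inhibition, read by sulforhodamine B assay, with a stated time of 72 h (a higher number here means a weaker inhibitor, a lower number a stronger inhibitor), the lowest of the three numbers measured so far; compound 2 `COc1ccc(C(=O)/C=C/c2cn(-c3ccccc3)nc2-c2ccsc2)c(OC)c1` gives 9000 nM and compound 3 `COc1cc(C(=O)/C=C/c2cn(-c3ccccc3)nc2-c2cccnc2)cc(OC)c1OC` gives 14500 nM. For the measured compounds named here, the only measured step, a 3.3-fold higher number from compound 1 to compound 2 (0.52 log units; beyond the scatter), concerns a methoxy group and does not touch the change in hand. Compound 4 `COc1cc(OC)c(C(=O)/C=C/c2cn(-c3ccccc3)nc2-c2cccnc2)c(OC)c1` differs from compound 1 by pyridin-3-yl in place of thiophen-3-yl on an aromatic carbon. Going by the values given here, no measured pair shows this swap on its own; compound 3 carries the same pyridin-3-yl group but a different arrangement of methoxy groups, and its number lies well above that of compound 1. A moderately higher number is therefore expected, a 2.2-fold higher number from compound 1 to compound 4 (0.35 log units; beyond the scatter). Compound 4 is estimated at 6000 nM, with a range from 2500 nM to 15000 nM.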

Compound 4, half-maximal inhibitory concentration: 1000 nM
Beside the measured number, compound 4's estimate is 6.0-fold (0.78 log units) above it; the measured number lies below the stated range.
By their numbers in this assay, from the lowest: compound 4; then compound 1; then compounds 2 and 3 (each within the scatter of the next).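

In this assay the swap gives a 2.7-fold lower number from compound 1 to compound 4 (0.43 log units; beyond the scatter) and so makes a stronger inhibitor, with the six-membered pyridin-3-yl in place of the five-membered thiophen-3-yl on the same carbon of the shared core. Among the compounds shown here, this is the first reading of this change on its own, and it shows that the number responds to which aromatic ring sits at this place. Nothing available explains why the number falls. Still open, going by these compounds, is whether plain phenyl, pyridin-4-yl or a pyridine carrying an amine would match pyridin-3-yl here.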